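The source may hold more compounds than are shown below. What is called first, only, known or untested is meant among the compounds shown, and "the series" means these compounds.

In an ADME assay on a cell-free system (plasma, Homo sapiens) for metabolic stability, read by LC-MS (on this read-out lower numbers stand for a shorter-lived compound and higher numbers for a longer-lived compound), compound 1 `NCc1ccc(C(=O)Nc2ccncc2)cc1-c1cccc(C(=O)OCC2CCCCC2)c1` gives 1.65 h. For the measured compounds named here, compound 2 `CCCCCOC(=O)c1cccc(-c2cc(C(=O)Nc3ccncc3)ccc2CN)c1` gives 0.967 h in this assay, the lowest of the two numbers so far, with compound 1 the nearest; the one step measured, a 1.7-fold lower number from compound 1 to compound 2 (0.23 log units; within the scatter), lies within the scatter. Compound 3 `NCc1ccc(C(=O)Nc2ccncc2)cc1-c1cccc(C(=O)OCC2CCCC2)c1` carries cyclopentyl in place of butyl on a saturated chain carbon bound to an oxygen next to a carbonyl group. That single step bears on the change: it too traded a ring for a chain on a saturated chain carbon bound to an oxygen next to a carbonyl group, and stayed within the scatter, so the expected step of a 1.3-fold higher number from compound 2 to compound 3 (0.13 log units; within the scatter) is small, if anything upward. Compound 3 is estimated at 1.3 h, with a range from 0.8 h to 2.2 h.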

Compound 3, half-life: 0.517 h
Estimate against measurement, compound 3: 2.5-fold (0.40 log units) above, outside the stated range (below it).
By their numbers in this assay, from the lowest: compounds 3, 2 and 1 (each within the scatter of the next, the first and the last beyond it).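

In this assay, for the compounds shown here, the change from cyclohexyl to cyclopentyl on a saturated chain carbon bound to an oxygen next to a carbonyl group gives the first step here beyond the scatter, though a modest one (a 3.2-fold lower number from compound 1 to compound 3 (0.50 log units; beyond the scatter)). Cyclopentyl in place of butyl stays within the scatter (a 1.9-fold lower number from compound 2 to compound 3 (0.27 log units; within the scatter)), so in these compounds the five-membered ring does not stand apart from the chain. Nothing available explains either step.

As far as these compounds go, how an amine, a carboxylic acid or a longer chain would read in this place remains open.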